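Working notes: from compound 3 to compound 4

This account rests on a few compounds, and the source may have more. Where it says the series, first, only, none or still open, it means among the compounds named here.

compound 1 `CNC(=O)c1cc(C(=O)NC2CC2)cn(CC2CCCCC2)c1=O` gives >= 148 ug/mL as a limit
compound 2 `CNC(=O)c1cc(C(=O)NC2CC2)cn(Cc2cccc([C@@H](C)O)c2)c1=O` gives >= 131 ug/mL as a limit
compound 3 `CNC(=O)c1cc(C(=O)NC2CC2)cn(CC2CCCOC2)c1=O` gives >= 131 ug/mL as a limit

In a physicochemical assay for solubility (on this read-out higher numbers stand for higher solubility and lower numbers for lower solubility), compound 3 has only the limit >= 131 ug/mL and no exact number. Compound 4 `CNC(=O)c1cc(C(=O)NC2CC2)cn(Cc2cccc3c2CCN3)c1=O` carries 2,3-dihydro-1H-indol-4-yl in place of oxan-3-yl on a saturated chain carbon bound to an aromatic nitrogen. The measured steps at this place are a step that the two limits leave unreadable from compound 1 to compound 2 and a step that the two limits leave unreadable from compound 1 to compound 3 and a step that the two limits leave unreadable from compound 2 to compound 3 and none has a size that can be read. Compound 2 also carries an aromatic ring here and still gives only a limit. The expected change is an at least 1.3-fold lower number from compound 3 to compound 4 (0.11 log units; that floor lies within the scatter) and it is estimated as a modest fall in this assay with wide uncertainty. Compound 4 is estimated at 100 ug/mL with an expected range of 35 ug/mL to 160 ug/mL for now.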

Compound 4, solubility: >= 184 ug/mL
Compound 4 ended at the assay's limit (the forecaster's own chance of this, stated with the estimate: 45%); at least 1.8-fold (0.26 log units) between middle value and limit.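

In this assay compound 4 gives >= 184 ug/mL, which is a limit. Its steps from compound 1, compound 2 and compound 3 all join two limits and cannot be read. The compounds shown leave open whether these four differ at all in this read-out.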